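Benzothiophenyl for methoxypropynyl: expected intrinsic clearance of compound 4

The source may hold more compounds than are shown below. What is called first, only, known or untested is meant among the compounds shown, and "the series" means these compounds.

Measured compounds: compound 1 `Nc1ccc(S(=O)(=O)N2CCN(c3ncc(C(O)(C(F)(F)F)C(F)(F)F)cc3C#CCO)CC2)cn1`, 65 mL.min-1.g-1; compound 2 `COCC#Cc1cc(C(O)(C(F)(F)F)C(F)(F)F)cnc1N1CCN(S(=O)(=O)c2ccc(N)nc2)CC1`, 399 mL.min-1.g-1; compound 3 `COc1ccc(-c2cc(C(O)(C(F)(F)F)C(F)(F)F)cnc2N2CCN(S(=O)(=O)c3ccc(N)nc3)CC2)cn1`, 265 mL.min-1.g-1.

In an ADME assay (liver) for metabolic stability, with Liver microsome (Rattus norvegicus) as the target, using microsomes and NADPH, with a stated time of 30 min, tested at 1 uM (on this read-out lower numbers stand for slow clearance and higher numbers for fast clearance), compound 2 gives the highest number of the three; the nearest is compound 3, at 265 mL.min-1.g-1, and the furthest is compound 1, as a 6.1-fold higher number from compound 1 to compound 2 (0.79 log units; beyond the scatter) shows. The step to compound 4 `Nc1ccc(S(=O)(=O)N2CCN(c3ncc(C(O)(C(F)(F)F)C(F)(F)F)cc3-c3ccc4sccc4c3)CC2)cn1` is 1-benzothiophen-5-yl in place of 3-methoxyprop-1-yn-1-yl on an aromatic carbon. The step that bears most on it is a 1.5-fold lower number from compound 2 to compound 3 (0.18 log units; within the scatter), where an aromatic group also replaced the alkyne on the same aromatic carbon. The step of a 4.1-fold higher number from compound 1 to compound 3 (0.61 log units; beyond the scatter) is less direct, since it also removes a hydroxyl. Compound 4 is therefore expected to show a 1.0-fold higher number from compound 2 to compound 4 (0.00 log units; within the scatter), no clear movement beyond the scatter. The estimate for compound 4 is 400 mL.min-1.g-1, with a range of 200 mL.min-1.g-1 to 800 mL.min-1.g-1.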

Compound 4, intrinsic clearance in microsomes: 487 mL.min-1.g-1
Compound 4: middle estimate off by 1.2-fold (0.09 log units), on the low side; low and high end bracket the measured number.
By their numbers in this assay, from the lowest: compound 1; then compounds 3, 2 and 4 (each within the scatter of the next).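

In this assay, the 1-benzothiophen-5-yl group at this position gives a number that cannot be told from that of the 3-methoxyprop-1-yn-1-yl group (a 1.2-fold higher number from compound 2 to compound 4 (0.09 log units; within the scatter)) or of the 6-methoxypyridin-3-yl group (a 1.8-fold higher number from compound 3 to compound 4 (0.26 log units; within the scatter)). Against the 3-hydroxyprop-1-yn-1-yl group the separation is clear (a 7.5-fold higher number from compound 1 to compound 4 (0.87 log units; beyond the scatter)), so among these four compounds only compound 1 stands apart.

From the compounds shown here alone, whether an amine or a carboxylic acid at this position would bring the number down towards that of compound 1 remains open. Nothing shown here explains why compound 1 stands apart.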